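The source may report more compounds than this note shows. Statements on the series, on what has been measured and on what is new or still open speak of the compounds shown alone.

Within the data shown here, compound 2 `NC(=O)C1CCN(c2nc(-c3cc(F)c(Cl)cc3F)nc3c2CS(=O)(=O)C3)CC1` stands at the higher of the two numbers measured so far. In a functional assay on HEK293 cells for agonist activity at Glucose-dependent insulinotropic receptor (Homo sapiens), read by reporter gene assay and cAMP accumulation, with a stated time of 6 h (a higher number here means that more compound is needed for the effect, a lower number that less compound is needed), compound 2 gives 21 nM, while compound 1 `NC(=O)CC1CCN(c2nc(-c3cc(F)c(Cl)cc3F)nc3c2CS(=O)(=O)C3)CC1` gives 8.3 nM. Among the measured compounds shown here, the only measured step is a 2.5-fold higher number from compound 1 to compound 2 (0.40 log units; beyond the scatter), so pulling the amide group one bond closer to the ring raised the number by a modest amount.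

Compound 3 `O=S1(=O)Cc2nc(-c3cc(F)c(Cl)cc3F)nc(N3CCC(O)CC3)c2C1` carries a further change at the same position: hydroxy in place of carbamoyl on a saturated ring carbon. For the measured compounds named here, no measured step covers this particular exchange, so the step from compound 1 to compound 2 is the only guide, and it shows that altering the group on this ring carbon moves the number, but not by a large amount. Since the carbamoyl group appears to matter in that step, its removal is expected to push the number higher again, with wide uncertainty about how far. The expected step is a 2.9-fold higher number from compound 2 to compound 3 (0.46 log units; beyond the scatter). Compound 3 is therefore estimated at 60 nM in this assay, with a likely range from 15 nM to 250 nM.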

Compound 3, effective concentration (reported as EC, without a stated level of effect): 14 nM
The estimate for compound 3 lay 4.3-fold (0.63 log units) above the measured number; the measured number lies below the stated range.
By their numbers in this assay, from the lowest: compounds 1, 3 and 2 (each within the scatter of the next, the first and the last beyond it).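

The carbamoyl group turns out not to be needed at this ring carbon: going from 4-carbamoylpiperidin-1-yl to 4-hydroxypiperidin-1-yl swaps three heavy atoms for a single oxygen, and this assay gives a 1.5-fold lower number from compound 2 to compound 3 (0.18 log units; within the scatter). The hydroxy compound also cannot be told apart from the compound with the longer carbamoylmethyl group, with a 1.7-fold higher number from compound 1 to compound 3 (0.23 log units; within the scatter), so it sits within the scatter of both amides even though those two differ from each other beyond it. This position therefore tolerates a much smaller group than the amides, and the data offer no measured property that could explain why.

The three compounds leave open whether any group containing oxygen or nitrogen is needed here, a question that a plain piperidine with only hydrogen on this ring carbon, or a methoxy group in place of hydroxy, would address. They also leave open how this position responds to an amine, a carboxylic acid or a longer chain such as hydroxyethyl, since all three groups shown are neutral and carry a hydrogen-bond donor and acceptor.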